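Shortening the imidazole chain from compound 3 to compound 4

The source may hold more compounds than are shown below. What is called first, only, known or untested is meant among the compounds shown, and "the series" means these compounds.

Values measured in a functional assay on ECa-109 cells (Homo sapiens) for antiproliferative activity, read by MTT assay, with a stated time of 48 h (on this read-out higher numbers stand for weaker inhibition and lower numbers for stronger inhibition), are as follows
- compound 1 (`Cn1cc(C2=C(c3n[nH]c4ncccc34)C(=O)NC2=O)c2ccccc21`) gives 46100 nM
- compound 2 (`Cn1cc(C2=C(c3nn(CCCN4CCCCC4)c4ncccc34)C(=O)NC2=O)c2ccccc21`) gives 42300 nM
- compound 3 (`Cn1cc(C2=C(c3nn(CCCCn4ccnc4)c4ncccc34)C(=O)NC2=O)c2ccccc21`) gives 23500 nM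

On these numbers compound 3 (23500 nM) cannot be told apart from the other two. Compound 4 (`Cn1cc(C2=C(c3nn(CCn4ccnc4)c4ncccc34)C(=O)NC2=O)c2ccccc21`) differs from compound 3 in one place (1H-imidazol-1-yl in place of 2-(1H-imidazol-1-yl)ethyl on a saturated chain carbon, two bonds along the chain from an aromatic nitrogen): 1H-imidazol-1-yl in place of 2-(1H-imidazol-1-yl)ethyl on a saturated chain carbon, two bonds along the chain from an aromatic nitrogen. Put another way, 4-(1H-imidazol-1-yl)butyl goes to 2-(1H-imidazol-1-yl)ethyl.

Among the compounds with values here, three measured steps bear on this, and all stay within the scatter (a 1.1-fold lower number from compound 1 to compound 2 (0.04 log units; within the scatter); a 2.0-fold lower number from compound 1 to compound 3 (0.29 log units; within the scatter); a 1.8-fold lower number from compound 2 to compound 3 (0.26 log units; within the scatter)). From the compounds shown here alone, only compound 3 offers a measured imidazole chain, so chain length itself is untested. From compound 3 (23500 nM), compound 4 is therefore expected to stay within the scatter in this assay. The expected step is a 1.3-fold higher number from compound 3 to compound 4 (0.11 log units; within the scatter) and its direction is uncertain. The estimated value for compound 4 is 30000 nM (expected range 14000 nM to 60000 nM).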

Compound 4, half-maximal inhibitory concentration: > 100000 nM
Compound 4: no number, only a limit; the forecaster's own chance of this, stated with the estimate: 3%; middle value at least 3.3-fold (0.52 log units) away from the limit.
By their numbers in this assay, from the lowest: compounds 3, 2 and 1 (each within the scatter of the next). At a limit, above all of these: compound 4.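

In this assay compound 4 gives no number, only a limit of the assay: the limit of > 100000 nM in this assay, at which 1 of the 4 values shown sits.

Until now, no change on the aromatic nitrogen had moved the number beyond the scatter, and chain length was untested. Going from 4-(1H-imidazol-1-yl)butyl to 2-(1H-imidazol-1-yl)ethyl gives an at least 4.2-fold higher number from compound 3 to compound 4 (0.62 log units; beyond the scatter), so the length of this imidazole chain matters in this series. The shorter chain also stands apart from the piperidine chain, with an at least 2.3-fold higher number from compound 2 to compound 4 (0.37 log units; beyond the scatter), and from plain hydrogen on that nitrogen, with an at least 2.1-fold higher number from compound 1 to compound 4 (0.33 log units; beyond the scatter), so a group here can weaken inhibition and not merely leave it unchanged.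

Still open, from the compounds shown here alone, is how a 3-(1H-imidazol-1-yl)propyl chain, or a pentyl chain ending in imidazole, would read. Also open, going by these compounds, is whether a morpholine at the end of the chain would follow the imidazole or the piperidine.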